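Amine swap on the acrylamide chain of compound 2

The source may report more compounds than this note shows. Statements on the series, on what has been measured and on what is new or still open speak of the compounds shown alone.

Measured so far:
Compound 1 `C=C(C)C(=O)Nc1cc2c(N3CCc4ccccc43)ncnc2cc1OC` gives 4830 nM in a functional assay on PC-3 cells (Homo sapiens) for antiproliferative activity, read by MTT assay, with a stated time of 72 h; on this read-out higher numbers stand for weaker inhibition and lower numbers for stronger inhibition.
Compound 2 `CCN(CC)C/C=C/C(=O)Nc1cc2c(N3CCc4ccccc43)ncnc2cc1OC` gives 3690 nM in this assay.

Compound 2 and compound 1 sit within the scatter of each other: a 1.3-fold lower number from compound 1 to compound 2 (0.12 log units; within the scatter). Compound 3 `COc1cc2ncnc(N3CCc4ccccc43)c2cc1NC(=O)/C=C/CN1CCCCC1` differs from compound 2 by piperidin-1-yl in place of diethylamino on a saturated chain carbon bound to a double-bonded chain carbon. Among the measured compounds shown here, the single measured step replaced the whole group on the carbonyl carbon and stayed within the scatter; no measured step touches the amine itself. For compound 3 the expected step is a 1.1-fold lower number from compound 2 to compound 3 (0.02 log units; within the scatter), none beyond the scatter. The estimate for compound 3 in this assay is 3500 nM, range 1500 nM to 8000 nM.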

Compound 3, half-maximal inhibitory concentration: 4180 nM
Compound 3: middle estimate off by 1.2-fold (0.08 log units), on the low side; the range from low to high includes it.
By their numbers in this assay, from the lowest: compounds 2, 3 and 1 (each within the scatter of the next).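

In this assay, among the compounds shown here, the change from diethylamino to piperidin-1-yl on a saturated chain carbon bound to a double-bonded chain carbon gives a 1.1-fold higher number from compound 2 to compound 3 (0.05 log units; within the scatter) and is the one measured step confined to the amine itself. Replacing 1-methylethenyl on a carbonyl carbon with 3-(piperidin-1-yl)prop-1-en-1-yl gives a 1.2-fold lower number from compound 1 to compound 3 (0.06 log units; within the scatter) and so leaves compound 3 within the scatter of compound 1 as well. No evidence on hand bears on these results.

From the compounds shown here alone, whether a morpholine or a dimethylamino group at this place would give a step beyond the scatter stays open. The same holds for a longer chain carrying the piperidine.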